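Swapping nitro for fluoro in a cell tolerance test

The compounds below may be only part of what the source reports. "The series", "measured", "known", "first", "only" and "open" are said of these compounds alone.

Three related compounds have been through an ADME assay on Vero cells (Chlorocebus sabaeus) for cytotoxicity, read by MTT assay, with a stated time of 72 h (a lower number here means that less compound is tolerated, a higher number that more compound is tolerated), yet they offer little to work with. Compound 1 (`O=C(N/N=C/c1ccc(O)cc1)c1ccc([N+](=O)[O-])o1`) has the entry "not determined" (no result reported). Compound 2 (`COc1ccc(/C=N/NC(=O)c2ccc([N+](=O)[O-])o2)cc1`) has the entry "not determined" (no result reported). Compound 3 (`C/C(=N\NC(=O)c1ccc([N+](=O)[O-])o1)c1ccc([N+](=O)[O-])cc1`) gives > 196000 nM, which is a limit of the assay and not a number. Going by the values given here, the only firm reading so far is therefore (the limit of > 196000 nM in this assay, at which 1 of the 3 values shown sits).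

Compound 4 (`C/C(=N\NC(=O)c1ccc([N+](=O)[O-])o1)c1ccc(F)cc1`) keeps the rest of compound 3 and changes one group: fluoro in place of nitro on an aromatic carbon. In words, this is fluoro in place of nitro on an aromatic carbon, para to a large group. Among the compounds with values here, no measured pair shows what this swap does in this assay, so the expectation rests on compound 3 alone, and it is a loose one. The expected change is an at least 1.3-fold lower number from compound 3 to compound 4 (0.11 log units; that floor lies within the scatter), a small move towards less compound being tolerated, and it may stay within the usual scatter. For compound 4 the estimate is 150000 nM, with an expected range from 40000 nM to 400000 nM.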

Compound 4, half-maximal cytotoxic concentration: 215000 nM
For compound 4 the middle estimate is 1.4-fold (0.16 log units) below the measured one; measured number inside the range.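

No step can be read from compound 3 to compound 4 in this assay, because compound 3 stands at a limit of the assay and not at a number: the limit of > 196000 nM in this assay, at which 1 of the 4 values shown sits.

The compounds shown leave open whether fluoro in place of nitro on an aromatic carbon raises, lowers or leaves unchanged the amount of compound tolerated.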